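Substituent variation at one aromatic carbon of the shared core

The source may hold more compounds than are shown below. What is called first, only, known or untested is meant among the compounds shown, and "the series" means these compounds.

Measured so far in a functional assay on A549 cells (Homo sapiens) for inhibition; a lower number here means a stronger inhibitor, a higher number a weaker inhibitor:
compound 1 `CCc1ccc(N2C(=O)C=CC2OCC(F)(F)F)cc1`: 8090 nM
compound 2 `CC(C)(C)c1ccc(N2C(=O)C=CC2OCC(F)(F)F)cc1`: 8500 nM
compound 3 `O=C1C=CC(OCC(F)(F)F)N1c1ccc(C(F)(F)F)cc1`: 8390 nM

Compound 1 carries the lowest of the three numbers, but the gaps to its neighbours are small: the step of a 1.0-fold higher number from compound 1 to compound 3 (0.02 log units; within the scatter) and the step of a 1.1-fold higher number from compound 1 to compound 2 (0.02 log units; within the scatter) both fall within the scatter, so the three compounds are not told apart by this assay.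

Compound 4 `O=C1C=CC(OCC(F)(F)F)N1c1ccc(Br)cc1` has not yet been measured. It differs from compound 1 by bromo in place of ethyl on an aromatic carbon. The bearing steps are the three substituent exchanges at this same carbon: a 1.1-fold higher number from compound 1 to compound 2 (0.02 log units; within the scatter), a 1.0-fold higher number from compound 1 to compound 3 (0.02 log units; within the scatter) and a 1.0-fold lower number from compound 2 to compound 3 (0.01 log units; within the scatter). Ethyl, tert-butyl and trifluoromethyl all give the same number within the scatter, so the group at this carbon has not moved the read-out across these three compounds. Bromo is one more group at the same place, and no step beyond the scatter is expected from it in either direction; the pattern rests on only three compounds.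

Compound 4 is therefore expected to give 8200 nM, in a range from 4000 nM to 17000 nM. The expected step of a 1.0-fold higher number from compound 1 to compound 4 (0.01 log units; within the scatter) is estimated to lie within the scatter.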

Compound 4, half-maximal inhibitory concentration: 6960 nM
Beside the measured number, compound 4's estimate is 1.2-fold (0.07 log units) above it; low and high end bracket the measured number.
By their numbers in this assay, from the lowest: compounds 4, 1, 3 and 2 (each within the scatter of the next).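

Bromo, one heavy atom in place of the two of ethyl, extends the flat reading in this assay to a halogen: the steps of a 1.2-fold lower number from compound 1 to compound 4 (0.07 log units; within the scatter) and a 1.2-fold lower number from compound 3 to compound 4 (0.08 log units; within the scatter) and a 1.2-fold lower number from compound 2 to compound 4 (0.09 log units; within the scatter) all stay within the scatter. This aromatic carbon, para to a large group, has now carried ethyl, tert-butyl, trifluoromethyl and bromo with no step beyond the scatter among the four compounds. Nothing available bears on why the read-out stays flat at this carbon.

As far as these compounds go, whether an amine, a carboxylic acid or a longer chain at this carbon would move the number remains open. From the compounds shown here alone, all four compounds share the rest of the core, so the effect of any change elsewhere on it also remains open.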